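Notes on the step from compound 3 to compound 4

This account rests on a few compounds, and the source may have more. Where it says the series, first, only, none or still open, it means among the compounds named here.

Compound 3 `O=c1ccn(CCCCCOc2ccc(Br)cc2)c(=O)[nH]1` is known in an ADME assay on HEL cells (Homo sapiens) for cytotoxicity (on this read-out higher numbers stand for lower toxicity in this test and lower numbers for higher toxicity in this test), only as a limit: compound 3 gives > 100000 nM, a limit and not a number. Compound 2 `Nc1ccc(OCCCCCn2ccc(=O)[nH]c2=O)cc1` sits at a limit as well, giving > 100000 nM in this assay. Compound 1 `O=c1ccn(CCCCCOc2ccc(Cl)cc2)c(=O)[nH]1` has no result in this assay; its entry reads "not determined" (no result reported). Going by the values given here, the only step among measured compounds, a step that the two limits leave unreadable from compound 2 to compound 3, cannot be read in size because both ends rest on (the limit of > 100000 nM in this assay, at which 2 of the 3 values shown sit).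

Compound 4 `Cc1cccc(OCCCCCn2ccc(=O)[nH]c2=O)c1` differs from compound 3 by 3-methylphenyl in place of 4-bromophenyl on an oxygen on a saturated carbon. No measured step touches this change of aryl group, and the single step shown is itself unreadable, so nothing in the data points to a direction. With two of three entries resting on (the limit of > 100000 nM in this assay, at which 2 of the 3 values shown sit), the expectation is that compound 4 also reaches the limit, and the expected step of a number no higher from compound 3 to compound 4 (the limit leaves the size open) is none beyond the scatter. Compound 4 is therefore estimated at 100000 nM, with a range from 40000 nM to 300000 nM.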

Compound 4, half-maximal cytotoxic concentration: > 100000 nM
Compound 4 gave a limit, no number (the forecaster's own chance of this, stated with the estimate: 80%); the middle value sits exactly at the limit.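

No new step can be read: compound 4 also gives only a limit, so its steps from compound 2 and from compound 3 stay unreadable, all resting on one ceiling: the limit of > 100000 nM in this assay, at which 3 of the 4 values shown sit.

The compounds shown leave open whether any aryl group in this series yields an actual number in this assay.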